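Replacing a dimethylphenyl ring with thiophene

This account rests on a few compounds, and the source may have more. Where it says the series, first, only, none or still open, it means among the compounds named here.

In a functional assay on PC-3 cells (Homo sapiens) for cytotoxicity (on this read-out lower numbers stand for an effect already at smaller amounts and higher numbers for an effect only at larger amounts of compound), compound 3 `COC1=C(C)C(=O)/C(=C(O)/C=C/c2c(C)cccc2C)C(=O)C1(C)C` gives 17.1 ug/mL. Compound 1 `COC1=C(C)C(=O)/C(=C(O)/C=C/c2cccc(OC)c2)C(=O)C1(C)C` gives 14.3 ug/mL, and the step between them is a 1.2-fold higher number from compound 1 to compound 3 (0.08 log units; within the scatter). Compound 2 `COC1=C(C)C(=O)/C(=C(O)/C=C/c2ccc(F)cc2)C(=O)C1(C)C` gives 7.2 ug/mL, and here the step is a 2.4-fold higher number from compound 2 to compound 3 (0.38 log units; beyond the scatter). The remaining pair shows a 2.0-fold lower number from compound 1 to compound 2 (0.30 log units; within the scatter). Compound 4 `COC1=C(C)C(=O)/C(=C(O)/C=C/c2cccs2)C(=O)C1(C)C` keeps the shared core and changes only the ring at the end of the chain: thiophen-2-yl in place of 2,6-dimethylphenyl on a double-bonded chain carbon bound to a double-bonded chain carbon. Going by the values given here, no measured compound carries a five-membered ring, so only these three ring swaps offer guidance, and the largest, a 2.4-fold higher number from compound 2 to compound 3 (0.38 log units; beyond the scatter), is modest. A small shift towards lower numbers, not clearly beyond the scatter, is therefore expected. The expected change is a 1.7-fold lower number from compound 3 to compound 4 (0.23 log units; within the scatter). Compound 4 is estimated at 10 ug/mL, within a range of 5 ug/mL to 20 ug/mL.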

Compound 4, concentration for half-maximal effect: 18.2 ug/mL
For compound 4 the middle estimate is 1.8-fold (0.26 log units) below the measured one, within the range that was stated.
By their numbers in this assay, from the lowest: compounds 2, 1, 3 and 4 (each within the scatter of the next, the first and the last beyond it).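

In this assay, thiophen-2-yl at this place gives a 1.1-fold higher number from compound 3 to compound 4 (0.03 log units; within the scatter) and a 1.3-fold higher number from compound 1 to compound 4 (0.10 log units; within the scatter), so the smaller five-membered ring with its sulfur atom cannot be told apart from these two six-membered rings. Only against 4-fluorophenyl does the new ring show a gap beyond the scatter, with a 2.5-fold higher number from compound 2 to compound 4 (0.40 log units; beyond the scatter). Nothing available explains this result. As far as these compounds go, whether an aromatic ring carrying an amine or a carboxylic acid would shift the number remains open. So does whether thiophen-3-yl would behave like thiophen-2-yl.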